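The compounds below may be only part of what the source reports. "The series", "measured", "known", "first", "only" and "open" are said of these compounds alone.

In a functional assay on HepG2 cells (Homo sapiens) for inhibition, read by MTT assay, with a stated time of 72 h (on this read-out higher numbers stand for weaker inhibition and lower numbers for stronger inhibition), compound 1 `COc1ccc(/C=C/C(=O)c2c(OC)cc(O)c(CC=C(C)C)c2O)cc1` gives 32400 nM, compound 2 `COc1cc(/C=C/C(=O)c2c(OC)cc(O)c(CC=C(C)C)c2O)ccc1O` gives 21700 nM and compound 3 `COc1ccc(/C=C/C(=O)c2c(OC)cc(O)c(CC=C(C)C)c2O)cc1OC` gives 13800 nM. Two measured steps end at that last value: a 2.3-fold lower number from compound 1 to compound 3 (0.37 log units; beyond the scatter), and a 1.6-fold lower number from compound 2 to compound 3 (0.20 log units; within the scatter). This leaves compound 3 clearly under compound 1 but level with compound 2. Compound 4 `COc1cc(/C=C/C(=O)c2c(OC)cc(O)c(CC=C(C)C)c2O)cc(OC)c1OC` carries one further change, methoxy in place of hydrogen on an aromatic carbon. Within the data shown here, the only measured step of the same kind is a 2.3-fold lower number from compound 1 to compound 3 (0.37 log units; beyond the scatter), and it was modest. A similar or smaller drop in this assay is therefore expected, which means an estimated 1.4-fold lower number from compound 3 to compound 4 (0.14 log units; within the scatter). The estimated value for compound 4 is 10000 nM, with an expected range of 5000 nM to 22000 nM.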

Compound 4, half-maximal inhibitory concentration: > 50000 nM
Compound 4: no number, only a limit; the forecaster's own chance of this, stated with the estimate: 5%; at least 5.0-fold (0.69 log units) between middle value and limit.
By their numbers in this assay, from the lowest: compounds 3, 2 and 1 (each within the scatter of the next, the first and the last beyond it). At a limit, above all of these: compound 4.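

Adding methoxy to an aromatic carbon does not have one fixed outcome in this series. The earlier addition gave a 2.3-fold lower number from compound 1 to compound 3 (0.37 log units; beyond the scatter), whereas this one, ortho to a methoxy group and meta to another, reverses the direction and gives an at least 3.6-fold higher number from compound 3 to compound 4 (0.55 log units; beyond the scatter). Compound 4 has only a limit in this assay, not a number: the limit of > 50000 nM in this assay, at which 1 of the 4 values shown sits.

From the compounds shown here alone, the true value of compound 4 therefore stays open. So does whether a fluorine or an amine on this same aromatic carbon would keep the number close to that of compound 3.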